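Series notes: aryl substituent exchange, compound 3 to compound 4

The source may report more compounds than this note shows. Statements on the series, on what has been measured and on what is new or still open speak of the compounds shown alone.

Measured so far in a functional assay for inhibition, with a stated time of 5 min, tested at 1 mM; a higher number here means more inhibition at the concentration tested (going by the name of the read-out), a lower number less inhibition:
compound 1 `COc1ccc(/C(Cl)=C/C=C(\C#N)C(=O)c2c(C)[nH]c3ccccc23)cc1` — 63.1%
compound 2 `COc1ccc(/C(Cl)=C/C=C(\C#N)C(=O)c2c[nH]c3ccc(Br)cc23)cc1` — 62.2%
compound 3 `N#C/C(=C\C=C(/Cl)c1ccc(Br)cc1)C(=O)c1c[nH]c2ccccc12` — 65.5%

Compound 3 holds the highest of the three numbers shown, but only on paper: the nearest of the others is compound 1 and the furthest is compound 2, and both sit within the scatter of compound 3. The three compounds therefore give no separation in this assay, and none of the numbers can be called higher or lower than another on these values. Within the data shown here, no pair among them differs in a single place, so no measured step exists.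

Compound 4 `COc1ccc(/C(Cl)=C/C=C(\C#N)C(=O)c2c[nH]c3ccccc23)cc1` has not yet been tested. It differs from compound 3 in one place: methoxy in place of bromo on an aromatic carbon. Compound 1 and compound 2 already carry the methoxy group and their values sit in the same band as compound 3, which gives no hint of a shift tied to this group, although each of them also differs elsewhere in the shared core. For the step from compound 3 to compound 4 in this assay no movement beyond the scatter is expected, in either direction. The estimate for compound 4 is 64%, with a range from 52% to 76%. This corresponds to an expected step of a number 1.5 percentage points lower from compound 3 to compound 4 (within the scatter).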

Compound 4, a percentage reported as inhibition, at one concentration (the size of the read-out at that concentration, not a potency): 61.3%
The estimate for compound 4 lay 2.7 percentage points above the measured number, and the stated range covers the measured number.
By their numbers in this assay, from the lowest: compounds 4, 2, 1 and 3 (each within the scatter of the next).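

In this assay, among these compounds, the change from 4-bromophenyl to 4-methoxyphenyl gives the first measured single-place step at this position, a number 4.2 percentage points lower from compound 3 to compound 4 (within the scatter), so bromo and methoxy on this aromatic carbon are not separated by this read-out. Compound 4 also provides two single-place steps on the other side of the molecule, with the methoxy group held constant: hydrogen in place of bromo on an aromatic carbon gives a number 0.9 percentage points lower from compound 2 to compound 4 (within the scatter), and hydrogen in place of methyl on an aromatic carbon gives a number 1.8 percentage points lower from compound 1 to compound 4 (within the scatter), so neither of these changes separates its pair of compounds either. The data at hand offer no explanation for any of these steps.

As far as these compounds go, with only bromo and methoxy compared at this position, it remains open whether a different group there, such as an amine, a carboxylic acid or a longer alkoxy chain, would move the number beyond the scatter. From the compounds shown here alone, because the read-out is taken at a single concentration and is not a potency, it also remains open whether compounds that are not separated here would differ in a full concentration series.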